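A Furan Amide Tested for Vero Cell Toxicity

The source may hold more compounds than are shown below. What is called first, only, known or untested is meant among the compounds shown, and "the series" means these compounds.

Compound 1 `CN(C)c1cc2[nH]c(C3CCCCC3)nc2cc1NC(=O)c1ccc(Br)cc1`: > 100 ug/mL (a limit of the assay, not a number)
Compound 2 `CN(C)c1cc2[nH]c(C3CCCCC3)nc2cc1NC(=O)c1cccc(Br)c1`: > 100 ug/mL (a limit of the assay, not a number)
Compound 3 `CCCCNC(=O)Nc1cc2nc(C3CCCCC3)[nH]c2cc1N(C)C`: > 100 ug/mL (a limit of the assay, not a number)

These three compounds share one core and differ only in the group attached to a carbonyl carbon. In an ADME assay on Vero cells (Chlorocebus sabaeus) for cytotoxicity, read by resazurin assay, with a stated time of 3 days (on this read-out higher numbers stand for weaker inhibition and lower numbers for stronger inhibition), none of them reached a numerical read-out; each result is the limit of > 100 ug/mL in this assay, at which 3 of the 3 values shown sit. Compound 3 therefore stands at the limit together with the other two, and no ordering among them can be drawn.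

Compound 4 `CN(C)c1cc2[nH]c(C3CCCCC3)nc2cc1NC(=O)c1ccco1` is the next member and differs from compound 3 by furan-2-yl in place of butylamino on a carbonyl carbon. The measured steps that touch this position are a step that the two limits leave unreadable from compound 1 to compound 3, a step that the two limits leave unreadable from compound 2 to compound 3 and a step that the two limits leave unreadable from compound 1 to compound 2. Because all three values are the limit of > 100 ug/mL in this assay, at which 3 of the 3 values shown sit, not one of these steps has a readable size or direction, so there is no basis for expecting a step beyond the scatter in this assay.

On that ground compound 4 is expected to come out at 100 ug/mL, within a range from 50 ug/mL to 200 ug/mL. The step of a number no higher from compound 3 to compound 4 (the limit leaves the size open) is expected to be nil, with the likeliest outcome again a limit rather than a number.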

Compound 4, half-maximal inhibitory concentration: > 100 ug/mL
Compound 4: a limit, no number (the forecaster's own chance of this, stated with the estimate: 80%); the middle value sits exactly at the limit.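

In this assay compound 4 gives > 100 ug/mL, a limit of the assay and not a number. Its steps from compound 1, compound 2 and compound 3 cannot be read in either size or direction: the limit of > 100 ug/mL in this assay, at which 4 of the 4 values shown sit. The compounds shown leave open whether any group on this carbonyl carbon changes the read-out.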